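A few compounds are considered here, and "the series" means these few. Any claim that something is new, unique, unknown or untested is made for them only; others in the source may bear on it.

Measured compounds in a functional assay on SW 1116 cells (Homo sapiens) for cytotoxicity, read by MTT assay, with a stated time of 48 h; a lower number here means a stronger inhibitor, a higher number a weaker inhibitor:
compound 1 `O=C(CSc1nnc(-c2ccncc2)o1)N/N=C/c1ccc([N+](=O)[O-])cc1`: 25800 nM
compound 2 `O=C(CSc1nnc(-c2ccncc2)o1)N/N=C/c1cc(Br)ccc1O`: 8150 nM
compound 3 `O=C(CSc1nnc(-c2ccncc2)o1)N/N=C/c1cc(Br)cc(Br)c1O`: 8570 nM

Compound 3 stands second highest of the three numbers in this assay; its nearest neighbour is compound 2, with a difference that lies within the scatter (a 1.1-fold higher number from compound 2 to compound 3 (0.02 log units; within the scatter)), and its furthest is compound 1 (a 3.0-fold lower number from compound 1 to compound 3 (0.48 log units; beyond the scatter)). The next compound, compound 4 `O=C(CSc1nnc(-c2ccncc2)o1)N/N=C/c1ccc(O)c(O)c1`, differs from compound 3 in one place: 3,4-dihydroxyphenyl in place of 3,5-dibromo-2-hydroxyphenyl on a carbon with a double bond to nitrogen.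

Among the measured compounds shown here, no measured step swaps one hydroxylated phenyl for another. For the measured compounds named here, the steps that bear on the change are a 3.2-fold lower number from compound 1 to compound 2 (0.50 log units; beyond the scatter) and a 3.0-fold lower number from compound 1 to compound 3 (0.48 log units; beyond the scatter), both modest and both toward a lower number when a hydroxyphenyl replaces the nitrophenyl, and a 1.1-fold higher number from compound 2 to compound 3 (0.02 log units; within the scatter), which shows that the bromine count made no difference beyond the scatter. Since the hydroxyl is kept in compound 4 and only the bromines are exchanged for a second hydroxyl, the expected step in this assay is small, with no clear direction beyond the scatter (a 1.1-fold higher number from compound 3 to compound 4 (0.02 log units; within the scatter)). Compound 4 is therefore estimated at 9000 nM, within a range of 3000 nM to 27000 nM.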

Compound 4, half-maximal inhibitory concentration: 1540 nM
The estimate for compound 4 lay 5.8-fold (0.77 log units) above the measured number; measured number below the stated range.
By their numbers in this assay, from the lowest: compound 4; then compounds 2 and 3 (each within the scatter of the next); then compound 1.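

In this assay, the group on the carbon with a double bond to nitrogen proves able to move the number even among hydroxylated phenyls, which the bromine change alone had not shown: 3,4-dihydroxyphenyl gives a 5.6-fold lower number from compound 3 to compound 4 (0.75 log units; beyond the scatter) and a 5.3-fold lower number from compound 2 to compound 4 (0.72 log units; beyond the scatter). Against the 4-nitrophenyl group the change reaches a 17-fold lower number from compound 1 to compound 4 (1.22 log units; beyond the scatter), the only large step in the set, and it makes compound 4 the strongest inhibitor of the four, with its steps to all the others beyond the scatter. Nothing available explains this gain.

These compounds cannot separate a contribution of the second hydroxyl from that of losing bromo or from the placing of the hydroxyls. As far as these compounds go, whether a 3,4-dimethoxyphenyl or a 4-aminophenyl group at this place would keep the lower number remains open.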